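Azole in Place of Amino on a Shared Core

The compounds below may be only part of what the source reports. "The series", "measured", "known", "first", "only" and "open" are said of these compounds alone.

Measured compounds in an in vitro assay on Sf21 cells for inhibition of high affinity 3',5'-cyclic-AMP phosphodiesterase 7A (Homo sapiens); on this read-out lower numbers stand for stronger inhibition and higher numbers for weaker inhibition:
- Compound 1, `CNc1nc(C#N)nc(NC2(C#N)CCCCC2)n1`: in this assay compound 1 gives only a limit, > 1000 nM.
- Compound 2, `CNc1nc(NC2(C#N)CCCCC2)nc(-n2cncn2)n1`: in this assay compound 2 gives only a limit, > 5000 nM.
- Compound 3, `CNc1nc(N)nc(NC2(C#N)CCCCC2)n1`: in this assay compound 3 gives "not determined" (no result reported).

Compound 3 therefore has no number of its own on this read-out; the two neighbouring values shown, the limit of > 1000 nM in this assay, at which 1 of the 3 values shown sits, and (the limit of > 5000 nM in this assay, at which 1 of the 3 values shown sits), are limits rather than numbers, so compound 3 stands among compounds for which only weak inhibition is recorded. The step from compound 3 to compound 4 (`CNc1nc(NC2(C#N)CCCCC2)nc(-n2cnc(C#N)n2)n1`) is 3-cyano-1H-1,2,4-triazol-1-yl in place of amino on an aromatic carbon.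

Among the compounds with values here, the only measured step, a step that the two limits leave unreadable from compound 1 to compound 2, exchanges cyano for 1H-1,2,4-triazol-1-yl and cannot be read in size because both ends are limits; it also does not concern the amino group. Within the data shown here, no measured step bears directly on the present change, so no direction or size can be inferred in this assay beyond the fact that both measured compounds are weak. Compound 4 is expected to show weak inhibition as well, with an estimated value around 3000 nM within the range 300 nM to 30000 nM.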

Compound 4, half-maximal inhibitory concentration: > 5000 nM
Compound 4: a limit, no number; the forecaster's own chance of this, stated with the estimate: 60%; middle value at least 1.6-fold (0.22 log units) from the limit.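

In this assay compound 4 gives only a limit, > 5000 nM. Its steps to compound 1 and compound 2 have limits at both ends, so neither can be read in size. The compounds shown leave open whether any change on the shared core alters inhibition.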